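Inverting a Ring Hydroxyl Stereocentre in a Kinase Inhibitor Series

The source may hold more compounds than are shown below. What is called first, only, known or untested is meant among the compounds shown, and "the series" means these compounds.

Compound 1 `N#Cc1cnc(NCc2cnccc2C(F)(F)F)cc1N[C@H]1C[C@@H](O)C1` gives 500 nM in an assay on isolated protein for inhibition of protein kinase C theta type (Homo sapiens), read by TR-FRET, with a stated time of 2 h; a lower number here means a stronger inhibitor, a higher number a weaker inhibitor.
Compound 2 `CC1(C)C[C@H](Nc2nc(NCc3cnccc3C(F)(F)F)ncc2C#N)CC[C@@H]1O` gives 6 nM in this assay.
Compound 3 `CC1(C)[C@@H](O)C[C@H]1Nc1nc(NCc2cnccc2C(F)(F)F)ncc1C#N` gives 4 nM in this assay.

Compound 3 holds the lowest number of the three, but its separation from compound 2 lies within the scatter, as shown by a 1.5-fold lower number from compound 2 to compound 3 (0.18 log units; within the scatter). Compound 1 sits far apart: compound 1 gives 500 nM, whereas compound 3 gives 4 nM, a gap well beyond the scatter.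

Compound 4 `CC1(C)[C@H](O)C[C@H]1Nc1nc(NCc2cnccc2C(F)(F)F)ncc1C#N` is the next step from compound 3. The two differ in this way: the two compounds have the same atoms and bonds and differ only in configuration as drawn: 1 of 2 stereo elements differ; a stereocentre at a saturated ring carbon is drawn S in compound 3 and R in compound 4. For the measured compounds named here, only one measured step exists, a 1.5-fold lower number from compound 2 to compound 3 (0.18 log units; within the scatter), and it exchanges one hydroxylated ring for another rather than inverting a centre; it stayed within the scatter. Going by the values given here, no measured pair shows what the inversion at the hydroxyl-bearing ring carbon does, so the expectation rests on the inversion being a small, contained change. The estimated step is a 3.0-fold higher number from compound 3 to compound 4 (0.48 log units; beyond the scatter), a mild rise. Compound 4 is therefore expected at 12 nM, within a range from 3 nM to 60 nM.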

Compound 4, half-maximal inhibitory concentration: 130 nM
The estimate for compound 4 lay 11-fold (1.03 log units) below the measured number; the measured number lies above the stated range.
By their numbers in this assay, from the lowest: compounds 3 and 2 (each within the scatter of the next); then compound 4; then compound 1.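

In this assay, for the compounds shown here, the 3-hydroxy-2,2-dimethylcyclobutyl group proves far less forgiving than the earlier compounds suggested: the only earlier step, a 1.5-fold lower number from compound 2 to compound 3 (0.18 log units; within the scatter), made the exchange of one hydroxylated ring for another look harmless, yet the inversion alone gives a 33-fold higher number from compound 3 to compound 4 (1.51 log units; beyond the scatter). The same ring exchange, read with the opposite configuration, gives a 22-fold higher number from compound 2 to compound 4 (1.34 log units; beyond the scatter), so the outcome of that exchange depends on how the ring carbon is drawn. The large loss can be placed on this one stereocentre because no atom or bond changes: the fact that compounds 3 and 4 differ only in the configuration as drawn.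

From the compounds shown here alone, whether the hydroxyl itself matters at this ring carbon stays open, as does whether a methoxy group or an amine there would respond to inversion in the same way. Going by these compounds, whether the 4-hydroxy-3,3-dimethylcyclohexyl ring depends equally on its configuration also remains unknown.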